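The source may report more compounds than this note shows. Statements on the series, on what has been measured and on what is new or still open speak of the compounds shown alone.

Measured so far:
Compound 1, `CCN(CC)CCCOc1c(OCc2ccccc2)cc(O)c2c(=O)cc(-c3ccccc3)oc12`, gives 3210 nM in a functional assay on MCF7 cells (Homo sapiens) for cytotoxicity, read by MTT assay, with a stated time of 72 h; on this read-out higher numbers stand for weaker inhibition and lower numbers for stronger inhibition.
Compound 2, `CN(C)CCCCOc1c(OCc2ccccc2)cc(O)c2c(=O)cc(-c3ccccc3)oc12`, gives 3210 nM in this assay.

Compound 2 stands level with compound 1 at the digits shown; the single measured step, no change at the digits printed from compound 1 to compound 2 (within the scatter), swapped the amine and lengthened the chain at once and did not move the read-out. Compound 3, `CCN(CC)CCCCOc1c(OCc2ccccc2)cc(O)c2c(=O)cc(-c3ccccc3)oc12`, differs from compound 2 in one place: diethylamino in place of dimethylamino on a saturated chain carbon, four bonds along the chain from an oxygen on an aromatic ring. This is the amine swap of that earlier step, run the other way, on the chain that compound 2 already carries. The expected step is therefore a 1.0-fold lower number from compound 2 to compound 3 (0.00 log units; within the scatter), none beyond the scatter, because no change at the digits printed from compound 1 to compound 2 (within the scatter) showed no movement even though it altered both the amine and the chain length. On that basis compound 3 is estimated at 3200 nM in this assay, with a range from 1500 nM to 7000 nM.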

Compound 3, half-maximal inhibitory concentration: 1920 nM
Compound 3: middle estimate off by 1.7-fold (0.22 log units), on the high side, and the stated range covers the measured number.
By their numbers in this assay, from the lowest: compounds 3, 1 and 2 (each within the scatter of the next).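

In this assay, putting diethylamino in place of dimethylamino, four bonds along the chain from an oxygen on an aromatic ring, gives a 1.7-fold lower number from compound 2 to compound 3 (0.22 log units; within the scatter) and so has no effect that can be told apart from the scatter at this position. With diethylamino kept, lengthening the chain gives a 1.7-fold lower number from compound 1 to compound 3 (0.22 log units; within the scatter) and likewise stays within the scatter, so the amine and the chain length, changed together in the earlier step, can now each be read alone. Nothing measured here explains why these steps are so small.

The compounds shown leave open whether a ring amine such as piperidine or morpholine at the end of this chain would shift the number beyond the scatter. They also leave open what a much longer chain, or a carboxylic acid in place of the amine, would do.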